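Swapping a cyclopropylamino for a methoxyethoxy chain

This account rests on a few compounds, and the source may have more. Where it says the series, first, only, none or still open, it means among the compounds named here.

Compound 1 `CCCCSc1nc(N)nc2c1ncn2/C=C1/CC1(CO)CO` gives in an ADME assay on Akata cells (Homo sapiens) for cytotoxicity, with a stated time of 7 days (on this read-out higher numbers stand for lower toxicity in this test and lower numbers for higher toxicity in this test), a reading of > 20000 nM, which is a limit of the assay and not a number.
Compound 2 `Nc1nc(NC2CC2)c2ncn(/C=C3/CC3(CO)CO)c2n1` gives in this assay a reading of > 20000 nM, again a limit rather than a number.
Compound 3 `CCCCCOc1nc(N)nc2c1ncn2/C=C1/CC1(CO)CO` gives in this assay a reading of > 20000 nM, also a limit.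

Compound 2 therefore stands where every measured compound stands: at the limit of > 20000 nM in this assay, at which 3 of the 3 values shown sit. None of the three shows a numerical toxicity value, so the three pairwise comparisons cannot be read. The step that the two limits leave unreadable from compound 1 to compound 2 is unreadable, as are a step that the two limits leave unreadable from compound 1 to compound 3 and a step that the two limits leave unreadable from compound 2 to compound 3. Nothing in this set tells whether the group on that aromatic carbon changes toxicity at all.

Compound 4 `COCCOc1nc(N)nc2c1ncn2/C=C1/CC1(CO)CO` differs from compound 2 by 2-methoxyethoxy in place of cyclopropylamino on an aromatic carbon. With all three shown compounds sitting at the limit, no measured step bears a readable size on this change, and no direction can be taken from the data. Compound 4 is expected to sit at or beyond the limit as well, as an estimate of 30000 nM, within a range of 15000 nM to 80000 nM. The estimated step that the limit leaves unreadable from compound 2 to compound 4 is expected to be none beyond the scatter, and the most likely outcome is that compound 4 again reports only a limit.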

Compound 4, half-maximal cytotoxic concentration: > 20000 nM
Compound 4: a limit, no number; the forecaster's own chance of this, stated with the estimate: 85%; the middle value is on the limit's open side.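

In this assay compound 4 gives > 20000 nM as its reading, a limit of the assay and not a number. Its steps from compound 1, compound 2 and compound 3 therefore cannot be read. Whether the group on that aromatic carbon changes toxicity at all stays open for the compounds shown: the limit of > 20000 nM in this assay, at which 4 of the 4 values shown sit.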